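A few compounds are considered here, and "the series" means these few. Any claim that something is new, unique, unknown or untested is made for them only; others in the source may bear on it.

Among the compounds with values here, in a functional assay on A549 cells (Homo sapiens) for antiproliferative activity, read by sulforhodamine B assay, with a stated time of 48 h (on this read-out lower numbers stand for stronger inhibition and higher numbers for weaker inhibition), compound 1 `COc1ccc(/C=C/C(=O)c2ccccc2-c2ccc(OC)c(OC)c2)cc1` gives 1600 nM, while compound 2 `COc1ccc(OC)c(/C=C/C(=O)c2ccccc2-c2ccc(OC)c(OC)c2)c1` gives 4100 nM, the higher and therefore weaker of the two numbers so far. Compound 3 `COc1ccc(-c2ccccc2C(=O)/C=C/c2ccc(Br)cc2)cc1OC` keeps the shared core and changes one group: 4-bromophenyl in place of 2,5-dimethoxyphenyl on a double-bonded chain carbon bound to a double-bonded chain carbon. Within the data shown here, only one measured step touches this place, a 2.6-fold higher number from compound 1 to compound 2 (0.41 log units; beyond the scatter), and it is modest, with 2,5-dimethoxyphenyl in place of 4-methoxyphenyl. Among the measured compounds shown here, no measured compound carries 4-bromophenyl, so this step is only a loose guide. Compound 3 loses the 2,5-dimethoxyphenyl group that goes with the higher number, so a modest move toward lower numbers in this assay is expected, roughly back toward compound 1 at 1600 nM. The expected change is a 2.1-fold lower number from compound 2 to compound 3 (0.31 log units; beyond the scatter). For compound 3 the estimated value is 2000 nM, with an expected range of 800 nM to 5000 nM.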

Compound 3, half-maximal inhibitory concentration: 6800 nM
Beside the measured number, compound 3's estimate is 3.4-fold (0.53 log units) below it, outside the stated range (above it).
By their numbers in this assay, from the lowest: compound 1; then compounds 2 and 3 (each within the scatter of the next).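

In this assay, 4-bromophenyl in place of 2,5-dimethoxyphenyl gives a 1.7-fold higher number from compound 2 to compound 3 (0.22 log units; within the scatter), so this assay does not separate these two quite different groups at this position. Bromo in place of methoxy on an aromatic carbon gives a 4.3-fold higher number from compound 1 to compound 3 (0.63 log units; beyond the scatter), which shows that the single methoxy group cannot be exchanged for bromo here without a real shift toward weaker inhibition, and 4-methoxyphenyl remains the group with the lowest number. Nothing available explains why these groups rank as they do.

Going by these compounds, it remains open whether the methoxy group itself matters or whether other small groups in its place, such as fluoro, methyl or hydroxy, would serve equally well. How an amine or a carboxylic acid on this ring would read in this assay is also unknown.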